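A few compounds are considered here, and "the series" means these few. Any claim that something is new, unique, unknown or untested is made for them only; others in the source may bear on it.

Series notes, a functional assay on MT4 cells (Homo sapiens) for cytotoxicity; on this read-out higher numbers stand for lower toxicity in this test and lower numbers for higher toxicity in this test:
compound 1 `CC(C)(C)[Si](C)(C)OC[C@H]1O[C@@H](n2cnc3c(N)ncnc32)[C@H](O[Si](C)(C)C(C)(C)C)[C@]12OS(=O)(=O)C=C2N` gives 13000 nM
compound 2 `COc1ncnc2c1ncn2[C@@H]1O[C@H](CO[Si](C)(C)C(C)(C)C)[C@@]2(OS(=O)(=O)C=C2N)[C@H]1O[Si](C)(C)C(C)(C)C` gives 21000 nM
compound 3 `CNc1ncnc2c1ncn2[C@@H]1O[C@H](CO[Si](C)(C)C(C)(C)C)[C@@]2(OS(=O)(=O)C=C2N)[C@H]1O[Si](C)(C)C(C)(C)C` gives 14000 nM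

Compound 1 carries the lowest of the three numbers as they stand, yet all three lie within the scatter of one another: a 1.6-fold higher number from compound 1 to compound 2 (0.21 log units; within the scatter), a 1.1-fold higher number from compound 1 to compound 3 (0.03 log units; within the scatter) and a 1.5-fold lower number from compound 2 to compound 3 (0.18 log units; within the scatter). On this read-out the three compounds share one level and nothing separates them.

Compound 4 `CC(C)(C)[Si](C)(C)OC[C@H]1O[C@@H](n2cnc3c(N)ncnc32)[C@H](O[Si](C)(C)C(C)(C)C)[C@@]12OS(=O)(=O)C=C2N` differs from compound 1 as follows: the two compounds have the same atoms and bonds and differ only in configuration as drawn: 1 of 4 stereo elements differ; a stereocentre at a saturated ring carbon is drawn R in compound 1 and S in compound 4. Among the compounds with values here, none of the measured steps concerns this stereocentre; each changed only a substituent on the aromatic ring and each stayed within the scatter. Within the data shown here, no measured step bears on a change of configuration, so no step beyond the scatter is expected in this assay in either direction. Compound 4 is estimated at 13000 nM, range 5000 nM to 35000 nM. The expected step is no change at the digits printed from compound 1 to compound 4 (within the scatter).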

Compound 4, half-maximal cytotoxic concentration: 7300 nM
Estimate against measurement, compound 4: 1.8-fold (0.25 log units) above; the range from low to high includes it.
By their numbers in this assay, from the lowest: compounds 4, 1, 3 and 2 (each within the scatter of the next, the first and the last beyond it).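

In this assay, the series now has its first reading on configuration rather than on an aromatic substituent: inverting this saturated ring carbon from R to S gives a 1.8-fold lower number from compound 1 to compound 4 (0.25 log units; within the scatter). Within the data shown here, at this stereocentre, the change in drawn configuration therefore stays at the level shared by the earlier compounds. The comparison isolates one variable: the fact that compounds 1 and 4 differ only in the configuration as drawn

Going by these compounds, whether the S configuration holds this level with methoxy or methylamino on the aromatic carbon remains open. Also open, on these data alone, is how either configuration reads with a free hydroxyl in place of the tert-butyldimethylsilyl ethers.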